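This account rests on a few compounds, and the source may have more. Where it says the series, first, only, none or still open, it means among the compounds named here.

Measured compounds:
- compound 1 `Cc1ccc(C(=O)Nc2ccc(O)c3c(=O)cc(-c4ccccc4Cl)oc23)cc1`: 16000 nM
- compound 2 `O=c1cc(-c2ccccc2Cl)oc2c(N3CCCC3)ccc(O)c12`: 9300 nM
- compound 3 `CS(=O)(=O)Nc1ccc(O)c2c(=O)cc(-c3ccccc3Cl)oc12`: 16000 nM

All three values come from a functional assay on ID8 cells (Mus musculus) for antiproliferative activity; a higher number here means a weaker inhibitor, a lower number a stronger inhibitor. Compound 3 stands level with compound 1, and both measured steps that reach it are small: no change at the digits printed from compound 1 to compound 3 (within the scatter) and a 1.7-fold higher number from compound 2 to compound 3 (0.24 log units; within the scatter).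

Compound 4 `O=c1cc(-c2ccccc2Cl)oc2c(NS(=O)(=O)c3cc(Cl)cc(Cl)c3O)ccc(O)c12` keeps the shared core and the sulfonamide nitrogen of compound 3, and carries 3,5-dichloro-2-hydroxyphenyl in place of methyl on a sulfonyl sulfur. Going by the values given here, no measured compound has an aromatic ring on a sulfonyl sulfur, so neither step measures this change directly. The nearest guide is compound 1, which has an aromatic ring on the carbonyl at the same nitrogen and gives 16000 nM, the same value as compound 3. On that evidence, only a modest shift is expected in this assay, with a slight lean towards a lower number. Among the compounds with values here, the chlorine and hydroxyl substituents have no counterpart among the measured compounds, so the range stays wide. The expected step is a 2.3-fold lower number from compound 3 to compound 4 (0.36 log units; beyond the scatter). For compound 4 the estimated value is 7000 nM, with an expected range from 1800 nM to 20000 nM.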

Compound 4, half-maximal inhibitory concentration: 24000 nM
Compound 4: the middle estimate sits 3.4-fold (0.54 log units) below what was measured, and the stated range ends below it.
By their numbers in this assay, from the lowest: compounds 2, 1, 3 and 4 (each within the scatter of the next, the first and the last beyond it).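

In this assay, going by these compounds alone, the sulfonyl sulfur is varied for the first time, and the change gives a 1.5-fold higher number from compound 3 to compound 4 (0.18 log units; within the scatter). Exchanging methyl for 3,5-dichloro-2-hydroxyphenyl adds a six-membered aromatic ring, two chlorines and a hydroxyl, yet this much larger group does not separate the two compounds in this assay, so the earlier finding that compound 1 and compound 3 cannot be told apart now has a counterpart on the sulfonyl sulfur itself. No measurement shown here offers any explanation for this result.

As far as these compounds go, what remains open is whether any group on the sulfonyl sulfur can move the number beyond the scatter, and whether the chlorines and the hydroxyl act separately or offset each other, which a plain phenyl, a 2-hydroxyphenyl or a 3,5-dichlorophenyl on that sulfur could begin to show. From the compounds shown here alone, it is also open whether a group of a different kind there, such as a carboxylic acid or a chain ending in an amine, would give a number that stands apart from those of compound 3 and compound 4.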